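The source may report more compounds than this note shows. Statements on the series, on what has been measured and on what is new or still open speak of the compounds shown alone.

Two compounds share one core and differ only in the group on the carbonyl carbon of the amide. Compound 1 `O=C(Nc1c(C(O)(C(F)(F)F)C(F)(F)F)ccc2ccccc12)C1CCCC1` carries a cyclopentyl there and, in an assay on LtK cells with ATP-sensitive inward rectifier potassium channel 11 (Homo sapiens) as the target (on this read-out lower numbers stand for an effect already at smaller amounts and higher numbers for an effect only at larger amounts of compound), compound 1 gives 495 nM. Compound 2 `O=C(Nc1c(C(O)(C(F)(F)F)C(F)(F)F)ccc2ccccc12)c1cccc(Cl)c1Cl` carries a 2,3-dichlorophenyl instead. In this assay compound 2 gives > 10000 nM, which is a limit of the assay and not a number. The change from compound 1 to compound 2 is large: an at least 20-fold higher number from compound 1 to compound 2 (1.30 log units; beyond the scatter). The limit itself is where compound 2 stands (the limit of > 10000 nM in this assay, at which 1 of the 2 values shown sits).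

Compound 3 `O=C(Nc1c(C(O)(C(F)(F)F)C(F)(F)F)ccc2ccccc12)c1cc(Cl)cc(Cl)c1` is the next step. It differs from compound 2 by 3,5-dichlorophenyl in place of 2,3-dichlorophenyl on a carbonyl carbon. Within the data shown here, no measured step compares two dichlorophenyl groups with one another, so the only bearing fact is that a dichlorophenyl on this carbonyl carbon, in compound 2, already sits at the limit. On that basis compound 3 is expected to stay near the limit, with the step of an at least 1.2-fold lower number from compound 2 to compound 3 (0.09 log units; that floor lies within the scatter) expected to lie within the scatter. The estimate for compound 3 is 8000 nM, in a range from 1500 nM to 30000 nM.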

Compound 3, half-maximal effective concentration: 306 nM
Beside the measured number, compound 3's estimate is 26-fold (1.42 log units) above it; measured number outside the range, below it.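

In this assay, the two groups have the same atoms joined differently, yet 3,5-dichlorophenyl in place of 2,3-dichlorophenyl on the carbonyl carbon gives an at least 32-fold lower number from compound 2 to compound 3 (1.51 log units; beyond the scatter), so at this position it matters where the two chlorines sit on the ring and not only that they are present. The value of compound 2 is a limit of the assay and not a number, so this step gives only a floor for the true difference: the limit of > 10000 nM in this assay, at which 1 of the 3 values shown sits. The other new step, a 1.6-fold lower number from compound 1 to compound 3 (0.21 log units; within the scatter), lies within the scatter, which shows that a dichlorophenyl group on this carbonyl carbon need not lose out to cyclopentyl, as compound 2 alone might have suggested.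

The compounds shown do not separate the contributions of the two chlorines, so it stays open how plain phenyl, 2-chlorophenyl or 3-chlorophenyl would compare on this carbonyl carbon. From the compounds shown here alone, it is also open whether groups other than chlorine, such as methyl or methoxy, placed as in 3,5-dichlorophenyl, would give values like that of compound 3.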